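The source may report more compounds than this note shows. Statements on the series, on what has been measured and on what is new or still open speak of the compounds shown alone.

In a functional assay on MOLT-4 cells (Homo sapiens) for antiproliferative activity (a higher number here means a weaker inhibitor, a lower number a stronger inhibitor), compound 3 `COc1cccc(-c2cc(N)c(C(=O)c3cc(OC)c(OC)c(OC)c3)s2)c1` gives 17 nM and holds the higher of the two exact numbers. Compound 2 `COc1cc(C(=O)c2sc(-c3ccccc3)cc2N)cc(OC)c1OC` gives 5.3 nM as its nearest neighbour. Compound 1 `COc1cc(C(=O)c2sc(-c3ccc(-c4ccccc4)cc3)cc2N)cc(OC)c1OC` reports only a limit, > 10000 nM in this case. Compound 4 `COc1cc(C(=O)c2sc(-c3ccc(C)cc3)cc2N)cc(OC)c1OC` carries 4-methylphenyl in place of 3-methoxyphenyl on an aromatic carbon relative to compound 3. For compound 4, which holds one ring there, the modest step of a 3.2-fold higher number from compound 2 to compound 3 (0.51 log units; beyond the scatter) seems a better guide than the large step of an at least 1800-fold lower number from compound 1 to compound 2 (3.27 log units; beyond the scatter) that came with hydrogen in place of phenyl. Little or no change beyond the scatter is therefore expected in this assay and its direction stays open. The expected shift is a 1.1-fold lower number from compound 3 to compound 4 (0.05 log units; within the scatter) by this estimate. For compound 4 the estimated value is 15 nM with an expected range from 4 nM to 70 nM in this assay.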

Compound 4, half-maximal inhibitory concentration: 16 nM
Compound 4: middle estimate off by 1.1-fold (0.03 log units), on the low side; the range from low to high includes it.
By their numbers in this assay, from the lowest: compound 2; then compounds 4 and 3 (each within the scatter of the next). At a limit, above all of these: compound 1.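

In this assay, the aromatic carbon next to the ring sulfur accepts 4-methylphenyl in place of 3-methoxyphenyl with no change beyond the scatter: a 1.1-fold lower number from compound 3 to compound 4 (0.03 log units; within the scatter). Against the unsubstituted phenyl, the methyl gives a 3.0-fold higher number from compound 2 to compound 4 (0.48 log units; beyond the scatter), a modest step like the one seen with methoxy. Methyl in place of the outer phenyl gives an at least 620-fold lower number from compound 1 to compound 4 (2.79 log units; beyond the scatter), a step that rests on a limit rather than a number: the limit of > 10000 nM in this assay, at which 1 of the 4 values shown sits.

On these data alone, how a chain longer than methyl, such as propyl or butyl, would fall between methyl and phenyl stays open. So does the effect of an amine or a carboxylic acid on this ring.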